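A few compounds are considered here, and "the series" means these few. Any claim that something is new, unique, unknown or untested is made for them only; others in the source may bear on it.

Within the data shown here, in an ADME assay on Vero cells (Chlorocebus sabaeus) for inhibition (on this read-out lower numbers stand for higher toxicity in this test and higher numbers for lower toxicity in this test), compound 2 (`COc1cccc(/C=C2\CCC/C(=C\c3ccccc3)C2=O)c1OC`) gives 33500 nM as the lower of the two numbers so far, and compound 1 (`COc1ccc(/C=C2\CCC/C(=C\c3ccc(N(C)C)cc3)C2=O)cc1`) gives 392000 nM on the less toxic side, a gap beyond the usual scatter. Compound 3 (`COc1cccc(/C=C2\CCC/C(=C\c3cccc(Br)c3)C2=O)c1OC`) departs from compound 2 in one place, with bromo in place of hydrogen on an aromatic carbon, meta to a large group (bromo in place of hydrogen on an aromatic carbon), so that phenyl becomes 3-bromophenyl. Among the measured compounds shown here, no measured pair in this set differs in only one place, so the data offer no direct precedent for this change. In this assay only a small shift toward lower numbers is expected, and none beyond the scatter. The expected change is a 1.2-fold lower number from compound 2 to compound 3 (0.08 log units; within the scatter) in this estimate. For compound 3 the expected value is 28000 nM and the expected range runs from 10000 nM to 80000 nM as a working estimate.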

Compound 3, half-maximal cytotoxic concentration: 31500 nM
Compound 3: middle estimate off by 1.1-fold (0.05 log units), on the low side, and the stated range covers the measured number.
By their numbers in this assay, from the lowest: compounds 3 and 2 (each within the scatter of the next); then compound 1.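

In this assay, the change from phenyl to 3-bromophenyl, with bromo in place of hydrogen on an aromatic carbon, meta to a large group, gives a 1.1-fold lower number from compound 2 to compound 3 (0.03 log units; within the scatter). The earlier compounds shown here offered no single-place comparison, and this first one shows that adding this one heavy atom at this place leaves the read-out within the scatter, so compound 2 and compound 3 cannot be told apart in this test. The data at hand offer no measured basis for explaining this result.

The compounds shown hold only hydrogen and bromo at this place, so it remains open whether fluoro, methoxy, an amine or a carboxylic acid there would behave the same way. A single step also leaves open whether bromo would give a similar result elsewhere on that ring.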